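Lengthening the ester chain on a migration inhibitor

This account rests on a few compounds, and the source may have more. Where it says the series, first, only, none or still open, it means among the compounds named here.

Of the compounds shown here, two sharing the same core have been measured in a functional assay on HT-1080 cells (Homo sapiens), read by transwell migration, with a stated time of 24 h, tested at 1 uM; on this read-out lower numbers stand for a stronger effect and higher numbers for a weaker effect at the one concentration tested. Compound 1, `CC(=O)OCc1ccc2oc(=O)c(C(=O)Nc3cccc(Cl)c3)cc2c1`, carries a short ester chain and an amide link to its chlorinated ring; in this assay compound 1 gives 66.9%. Compound 2, `CCCC(=O)OCc1ccc2oc(=O)c(C(=O)Oc3cccc(Br)c3)cc2c1`, has a longer ester chain and an ester link to a brominated ring; in this assay compound 2 gives 50.5%. Of the two numbers, compound 2 stands lowest, with compound 1 lying higher by a margin beyond the usual scatter, so compound 2 shows the stronger effect at the concentration tested.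

Compound 3, `CCCCCC(=O)OCc1ccc2oc(=O)c(C(=O)Oc3cccc(Br)c3)cc2c1`, differs from compound 2 in one place: ethyl in place of hydrogen on a saturated chain carbon, three bonds along the chain from a carbonyl carbon. Within the data shown here, no pair of measured compounds differs in this way, so the size of this step is not known from the data. The expectation is a change of a number 2.5 percentage points lower from compound 2 to compound 3 (within the scatter), small and within the scatter. On that basis compound 3 is estimated to give 48% in this assay, with a plausible range from 35% to 62%.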

Compound 3, a percentage reported as activity, at one concentration (the size of the read-out at that concentration, not a potency): 59.3%
Estimate against measurement, compound 3: 11.3 percentage points below; low and high end bracket the measured number.
By their numbers in this assay, from the lowest: compounds 2, 3 and 1 (each within the scatter of the next, the first and the last beyond it).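

Among these compounds, this pair is the first to isolate the ester chain: the rest of the molecule stays the same, whereas compounds 1 and 2 differ in several places at once and could not separate the contribution of the chain from the others. In this assay, placing ethyl in place of hydrogen on a saturated chain carbon, three bonds along the chain from a carbonyl carbon, turns propyl into pentyl and gives a number 8.8 percentage points higher from compound 2 to compound 3 (within the scatter); at this position and at this one concentration, the assay therefore does not tell the two chains apart. No further measurement bears on how this result arises.

Among the compounds shown here, only this single chain change on this single background is available, so it remains open whether a longer chain than the pentyl of compound 3, or a chain ending in an amine or a carboxylic acid, would shift the read-out beyond the scatter. Also open, from the compounds shown here alone, is whether the same lengthening would read the same way on the amide-linked, chlorinated ring of compound 1.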